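The source may report more compounds than this note shows. Statements on the series, on what has been measured and on what is new or still open speak of the compounds shown alone.

Working notes on the series

Compound 1 `O=C(Nc1ccc(OC(F)(F)F)c(F)c1)NC1CCN(C(=O)C2CC2)CC1` gives 19 ug/mL in a physicochemical assay for solubility, read by mass spectrometry, in phosphate buffer, with a stated time of 24 h, at pH 7.4; a lower number here means a less soluble compound, a higher number a more soluble compound. Compound 2 `O=C(Nc1ccc(C(F)(F)F)c(F)c1)NC1CCN(C(=O)C2CC2)CC1` gives 0.46 ug/mL. The two differ by trifluoromethyl in place of trifluoromethoxy on an aromatic carbon, and the step is a 41-fold lower number from compound 1 to compound 2 (1.62 log units; beyond the scatter).

Compound 3 `O=C(Nc1ccc(OC(F)(F)F)cc1)NC1CCN(C(=O)[C@@H]2CCOC2)CC1` gives 23 ug/mL; its value and that of compound 1 lie within the scatter of each other, so no order between them is read. How the core of compound 3 differs from the core of compound 1 is not broken down here.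

Compound 4 `O=C(Nc1ccc(C(F)(F)F)cc1)NC1CCN(C(=O)[C@@H]2CCOC2)CC1` is not yet measured. It differs from compound 3 by trifluoromethyl in place of trifluoromethoxy on an aromatic carbon. For the measured compounds named here, this is the same kind of change as the one from compound 1 to compound 2, but the surroundings are not identical: in compound 1 the changed group sits ortho to a fluoro group (1 heavy atom), in compound 3 it does not. Taking the earlier step as the only guide, the expected step is a 23-fold lower number from compound 3 to compound 4 (1.36 log units; beyond the scatter), somewhat less steep than the measured one given the missing fluoro group, with wide uncertainty. Compound 4 is therefore expected to give about 1 ug/mL, within 0.3 ug/mL to 4 ug/mL.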

Compound 4, solubility: 1.4 ug/mL
For compound 4 the middle estimate is 1.4-fold (0.15 log units) below the measured one, within the range that was stated.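

In this assay, trifluoromethyl in place of trifluoromethoxy on an aromatic carbon has now been read on two cores: a 16-fold lower number from compound 3 to compound 4 (1.22 log units; beyond the scatter) stands alongside a 41-fold lower number from compound 1 to compound 2 (1.62 log units; beyond the scatter), both beyond the scatter and both in the same direction, and no pair shown goes against this. That agreement covers these two pairs only: the core of compound 1 and the core of compound 3 are not broken down into single changes, so the pairs do not show which difference between them, if any, bears on the size of the step, and they set no rule for other cores. Nothing measured here gives a reason for the step on either core.

From the compounds shown here alone, whether other groups at the same place, such as a nitrile, a methoxy group or a chlorine atom, would follow trifluoromethyl or trifluoromethoxy stays open. Also open, going by these compounds, is whether the same step would appear on a core carrying an amine or a carboxylic acid.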